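Two limits and a smaller carbamate

The source may hold more compounds than are shown below. What is called first, only, known or untested is meant among the compounds shown, and "the series" means these compounds.

- compound 1 `COc1cc2ncnc(-n3nc(-c4ccccn4)nc3N)c2cc1OCCCN1CC(C)OC(C)C1`: > 25000 nM (a limit)
- compound 2 `COc1cc2ncnc(-n3nc(-c4ccccn4)nc3N)c2cc1OCCCCNC(=O)OC(C)(C)C`: > 7000 nM (a limit)

Both compounds were tested in an ADME assay on BJ cells (Homo sapiens) for cytotoxicity, with a stated time of 72 h; on this read-out lower numbers stand for an effect already at smaller amounts and higher numbers for an effect only at larger amounts of compound. In this assay compound 2 stands at > 7000 nM, which is a limit and not a number. The only other result, (the limit of > 25000 nM in this assay, at which 1 of the 2 values shown sits), is also a limit.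

Compound 3 `COc1cc2ncnc(-n3nc(-c4ccccn4)nc3N)c2cc1OCCCNC(=O)OC(C)C` has (isopropoxycarbonyl)amino in place of ((tert-butoxycarbonyl)amino)methyl on a saturated chain carbon, three bonds along the chain from an oxygen on an aromatic ring.

Among the measured compounds shown here, only one measured step bears on this change, a step that the two limits leave unreadable from compound 1 to compound 2, and it offers no size to build on. No step beyond the usual scatter is therefore expected, and another limit is the likeliest report. The expected change is a step that the limit leaves unreadable from compound 2 to compound 3. For compound 3 the estimated value is 10000 nM, with an expected range of 4000 nM to 30000 nM.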

Compound 3, half-maximal effective concentration: > 13000 nM
Compound 3: a limit, no number; the forecaster's own chance of this, stated with the estimate: 70%; middle value at least 1.3-fold (0.11 log units) away from the limit.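

Among the compounds shown here, compound 1, compound 2 and compound 3 each give only a limit in this assay, not a number, so no step among them can be read. The compounds shown leave open at what concentration each one produces its half-maximal effect, and whether these side-chain changes shift it.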